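The compounds below may be only part of what the source reports. "The series", "measured", "known", "first", "only" and "open" are said of these compounds alone.

Compounds measured so far in an assay on CHO cells for displacement of a labelled ligand from Substance-P receptor (Homo sapiens); a lower number here means a stronger inhibitor, a higher number a weaker inhibitor:

Compound 1, `COc1cccc(-c2[nH]c3ccc(C)cc3c2CCC(=O)N2CCN(c3ccccc3OC)CC2)c1`: 8 nM
Compound 2, `COc1ccccc1N1CCN(C(=O)CCc2c(-c3ccc(Br)cc3)n(C)c3ccc(C)cc23)CC1`: 0.14 nM

Compound 2 has the lowest number of the two. Compound 1 gives 8 nM in this assay, and compound 2 gives 0.14 nM; the gap between them is well beyond the scatter. The two differ in more than one place, so nothing is claimed here about what any single change does between them.

Compound 3, `COc1ccccc1N1CCN(C(=O)CCc2c(-c3ccc(C(F)(F)F)cc3)n(C)c3ccc(C)cc23)CC1`, is not yet measured in this assay. It differs from compound 2 in one place: trifluoromethyl in place of bromo on an aromatic carbon. Within the data shown here, no earlier pair shows this change, so its effect cannot be read from a measured step. The change is confined to a single substituent on the aromatic ring, with no change in ring count, donors, acceptors or charge. The expectation for this step is therefore no shift beyond the scatter, in either direction; compound 3 is expected to stay close to compound 2, with the step of a 1.4-fold higher number from compound 2 to compound 3 (0.15 log units; within the scatter) as the working estimate. Compound 3 is estimated at 0.2 nM in this assay, with a range from 0.07 nM to 0.6 nM.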

Compound 3, half-maximal inhibitory concentration: 0.14 nM
For compound 3 the middle estimate is 1.4-fold (0.15 log units) above the measured one; low and high end bracket the measured number.
By their numbers in this assay, from the lowest: compounds 2 and 3 (each within the scatter of the next); then compound 1.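

In this assay, trifluoromethyl in place of bromo on an aromatic carbon, para to a large group, gives no change at the digits printed from compound 2 to compound 3 (within the scatter), the only step shown that differs in a single place. At this position, a substituent of four heavy atoms with no hydrogen-bond donors, hydrogen-bond acceptors or net charge can replace a single bromine without leaving the scatter, and compound 3 gives 0.14 nM. No measured data on these compounds bear on why the two substituents read alike.

From the compounds shown here alone, only bromo and trifluoromethyl form a one-place pair at this position, and it remains open whether an amine, a carboxylic acid or a longer alkyl chain there would stay at the same level. Among these compounds, the gap between compound 1 and compound 2 also remains unassigned among the several places in which those two compounds differ, and the methoxyphenyl piperazine amide end shared by all three compounds has no one-place pair of its own.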